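Alkyl substitution on the shared bicyclic core

The source may report more compounds than this note shows. Statements on the series, on what has been measured and on what is new or still open speak of the compounds shown alone.

Compound 1 `Nc1ncnc(N2CCN(c3cccc(Cl)c3)CC2)c1[N+](=O)[O-]` — 85 nM
Compound 2 `Cc1ccc(Cl)cc1N1CCN(c2ncnc3[nH]ncc23)CC1` — 13 nM
Compound 3 `Cc1nc(N2CCN(c3cc(Cl)ccc3C)CC2)c2cn[nH]c2n1` — > 2000 nM (a limit of the assay)

In an assay for inhibition of ribosomal protein S6 kinase beta-1 variant D18H,T412E (Homo sapiens), read by a luciferase reporter and chemiluminescence, with a stated time of 3 h (on this read-out lower numbers stand for stronger inhibition and higher numbers for weaker inhibition), compound 2 gives 13 nM, the lowest of the two numbers shown. Compound 1 gives 85 nM, a higher number beyond the scatter. For compound 3 the assay reports only a limit, > 2000 nM, not a number.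

Compound 4 `CCCc1n[nH]c2ncnc(N3CCN(c4cc(Cl)ccc4C)CC3)c12` differs from compound 2 in one place: propyl in place of hydrogen on an aromatic carbon. Going by the values given here, the only measured step that bears on adding an alkyl group to the core is the methyl step from compound 2 to compound 3, where the number rose an at least 150-fold higher number from compound 2 to compound 3 (2.18 log units; beyond the scatter); that rise runs up to the assay limit (the limit of > 2000 nM in this assay, at which 1 of the 3 values shown sits). The propyl in compound 4 sits on a different aromatic carbon, on the five-membered ring next to the ring nitrogen, so the measured step is only a rough guide. Given the large loss from compound 2 to compound 3 after a small alkyl addition, a weaker number for compound 4 is expected, though the size is uncertain. Compound 4 is estimated at 150 nM, range 30 nM to 1000 nM, which would mean an expected step of a 12-fold higher number from compound 2 to compound 4 (1.06 log units; beyond the scatter).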

Compound 4, half-maximal inhibitory concentration: 6 nM
Compound 4: middle estimate off by 25-fold (1.40 log units), on the high side, outside the stated range (below it).
By their numbers in this assay, from the lowest: compound 4; then compound 2; then compound 1. At a limit, above all of these: compound 3.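

In this assay, propyl in place of hydrogen on this aromatic carbon, on the five-membered ring and next to the ring nitrogen, gives a 2.2-fold lower number from compound 2 to compound 4 (0.34 log units; beyond the scatter), so the shared core takes an alkyl chain here with a modest gain and no loss. Going by these compounds alone, the only earlier alkyl step on the core, the methyl on a different aromatic carbon, gives an at least 150-fold higher number from compound 2 to compound 3 (2.18 log units; beyond the scatter), so across these two steps the outcome of alkyl addition depends on which carbon of the core carries it. Compound 3 stands at > 2000 nM, which is a limit of the assay and not a number.

Still open, as far as these compounds go, is whether the gain at this carbon holds with a methyl, a longer chain, a cyclopropyl ring, an amine or a carboxylic acid in place of the propyl, and compound 4 alone cannot separate these cases. Nothing shown gives a reason for the gain at this carbon.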